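A few compounds are considered here, and "the series" means these few. Any claim that something is new, unique, unknown or untested is made for them only; others in the source may bear on it.

Measured in a functional assay on the whole organism (strain albino) for inhibition, with Rattus norvegicus as the target, read by paw edema, with stated times of 30 min and 4 h, at a dose of 0.28 mmol/kg by the oral route; on this read-out lower numbers stand for less inhibition and higher numbers for more inhibition at the one dose given (going by the name of the read-out):

Compound 1 `COc1cc(-c2nnc(SCC(=O)Nc3ccc(/C(C)=N/O)cc3)n2-c2ccccc2)cc(OC)c1OC`: 75%
Compound 2 `C=CCn1c(SCC(=O)Nc2ccc(C(C)=O)cc2)nnc1-c1ccc(OC)cc1`: 68%
Compound 3 `C=CCn1c(SCC(=O)Nc2ccc(/C(C)=N/O)cc2)nnc1-c1cc(OC)c(OC)c(OC)c1`: 72%

Compound 3 and compound 1 share a core and differ in one place, (phenyl in place of allyl on an aromatic nitrogen). The resulting step, a number 3 percentage points higher from compound 3 to compound 1 (within the scatter), leaves the two values within the scatter of each other. Compound 2 gives the lowest of the three numbers, but its gaps to compound 3 and to compound 1 both lie within the scatter, so no order among the three can be claimed. The difference between the core of compound 2 and the core of compound 3 is not broken down here.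

Compound 4 `COc1ccc(-c2nnc(SCC(=O)Nc3ccc(C(C)=O)cc3)n2-c2ccccc2)cc1` has not yet been measured in this assay. It differs from compound 2 by phenyl in place of allyl on an aromatic nitrogen. This is the same kind of change as that from compound 3 to compound 1, not the same one: in compound 2 the place is next to the ring atom that bears a 4-methoxyphenyl group and next to the ring atom that bears a large group, whereas in compound 3 it is next to two ring atoms that each bear a large group. Resting on the small earlier step of a number 3 percentage points higher from compound 3 to compound 1 (within the scatter), the expected step is of similar size, a number 3 percentage points higher from compound 2 to compound 4 (within the scatter). Compound 4 is therefore estimated at 71%, with a range from 61% to 80%.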

Compound 4, a percentage reported as inhibition, in the whole organism at one dose (the size of the read-out at that dose, not a potency): 63%
Compound 4: the middle estimate sits 8 percentage points above what was measured; the range from low to high includes it.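

Placed on the core of compound 2, phenyl in place of allyl on the aromatic nitrogen gives a number 5 percentage points lower from compound 2 to compound 4 (within the scatter) in this assay. Set beside the earlier case, the two steps cannot be told apart: the same change on two cores in this assay, a number 3 percentage points higher (within the scatter) from compound 3 to compound 1 and a number 5 percentage points lower (within the scatter) from compound 2 to compound 4, 8 percentage points apart, within the scatter of two such steps. On these two cores, then, the change gives no step beyond the scatter in either case, and nothing here marks it as behaving differently from one core to the other, though the opposite signs of the two small steps give no consistent direction to carry forward, and two pairs at a single dose cannot show that the change transfers across the series.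

The compounds shown leave open what a benzyl group or a longer chain on that aromatic nitrogen would do in this assay. They also leave open whether any replacement of allyl at this place, on either core, can give a step that clears the scatter.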